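Methoxy in place of hydrogen: expected effect on dose

The source may hold more compounds than are shown below. What is called first, only, known or untested is meant among the compounds shown, and "the series" means these compounds.

Of the compounds shown here, two carry a measured value so far: compound 1 `O=C(Nc1ccc(Cl)cc1)Nc1ccc(C(=O)/C=C/c2ccccc2)cc1` and compound 2 `O=C(/C=C/c1ccccc1)c1ccc(NC(=S)Nc2ccc(Cl)cc2)cc1`. In a functional assay on the whole organism (Abdomen, strain Swiss) with Mus musculus as the target, with a stated time of 30 min (a lower number here means that less compound is needed, a higher number that more compound is needed for the effect), compound 1 gives 7.25 umol/kg, the higher of the two numbers. In this assay compound 2 gives 3.03 umol/kg, and the gap between the two lies beyond the usual scatter, so more of compound 1 is needed for the effect than of compound 2. Within the data shown here, no pair of measured compounds differing in a single place has been recorded, so nothing measured speaks directly to the change that leads to compound 3 `COc1ccc(/C=C/C(=O)c2ccc(NC(=O)Nc3ccc(Cl)cc3)cc2)cc1`.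

Among the measured compounds shown here, compound 3 differs from compound 1 in one place: methoxy in place of hydrogen on an aromatic carbon With no measured pair showing what this change does, the expectation rests on the value of compound 1 alone. In this assay the step of a 1.1-fold lower number from compound 1 to compound 3 (0.05 log units; within the scatter) is expected to lie within the scatter, in no particular direction. Compound 3 is therefore estimated to give 6.5 umol/kg in this assay, within a range from 2.5 umol/kg to 16 umol/kg.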

Compound 3, dose for 50% inhibition: 31.1 umol/kg
The estimate for compound 3 lay 4.8-fold (0.68 log units) below the measured number, and the stated range ends below it.
By their numbers in this assay, from the lowest: compound 2; then compound 1; then compound 3.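

In this assay, among these compounds, phenyl to 4-methoxyphenyl gives a 4.3-fold higher number from compound 1 to compound 3 (0.63 log units; beyond the scatter) and is the first single-place step available. It shows that the aromatic carbon para to a large group is not indifferent to substitution: with methoxy in place of hydrogen there, more compound is needed for the effect, and the step lies beyond the usual scatter. No measurement at hand offers an explanation for this step.

Among the compounds shown here, with only one group tested at this place, the step cannot be assigned to methoxy specifically rather than to any replacement of hydrogen, so it remains open whether a fluorine atom, a hydroxy group, an amine, a carboxylic acid or a longer chain such as ethoxy would shift the number in the same direction or by a similar amount. As far as these compounds go, it also remains open whether methoxy in place of hydrogen at the same place on compound 2 would produce a step of similar direction and size, since the present step rests on a single pair.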